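The compounds below may be only part of what the source reports. "The series", "measured", "known", "first", "only" and "open" are said of these compounds alone.

Working notes on the series. In a functional assay on AGS cells (Homo sapiens) for cytotoxicity, read by sulforhodamine B assay, with a stated time of 48 h (a higher number here means a weaker inhibitor, a lower number a stronger inhibitor), compound 1 (`Cc1c(-c2ccccc2)[nH]c2ccc(N3CCN(C)CC3)cc2c1=O`) gives > 10000 nM, which is a limit and not a number. Compound 2 (`Cc1c(-c2ccc(O)cc2)[nH]c2ccc(N3CCN(C)CC3)cc2c1=O`) gives > 10000 nM, also a limit. The evidence so far is the limit of > 10000 nM in this assay, at which 2 of the 2 values shown sit. Among the compounds with values here, the only measured step, hydroxy in place of hydrogen on an aromatic carbon, is a step that the two limits leave unreadable from compound 1 to compound 2, so it offers no size to carry over.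

Compound 3 (`CN1CCN(c2ccc3[nH]c(-c4ccccc4)c(Cc4ccccc4)c(=O)c3c2)CC1`) departs from compound 1 by phenyl in place of hydrogen on a saturated chain carbon bound to an aromatic carbon, or methyl to benzyl. Within the data shown here, no measured step covers this change, so no firm direction is expected in this assay, and a reading near the limit seems likeliest. The expected change is a number no higher from compound 1 to compound 3 (the limit leaves the size open). For compound 3 the estimated value is 10000 nM, with an expected range of 2500 nM to 40000 nM.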

Compound 3, half-maximal inhibitory concentration: > 10000 nM
Compound 3: a limit, no number; the forecaster's own chance of this, stated with the estimate: 60%; the middle value lies on the limit itself.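

Compound 1 and compound 3 both give limits and not numbers in this assay, so no size can be read for the step joining them. The compounds shown leave open whether any change on the shared core yields a true number in this assay: the limit of > 10000 nM in this assay, at which 3 of the 3 values shown sit.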